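A few compounds are considered here, and "the series" means these few. Any claim that something is new, unique, unknown or untested is made for them only; others in the source may bear on it.

Compound 1 `COc1cc(N(Cc2ccc(Br)cc2)C(=O)CSc2nc3ccccc3s2)cc(OC)c1OC` and compound 2 `COc1cc(CN(C(=O)CSc2nc3ccccc3s2)c2cc(OC)c(OC)c(OC)c2)cc(OC)c1OC` share their core with compound 3 `COc1ccc(CN(C(=O)CSc2nc3ccccc3s2)c2cc(OC)c(OC)c(OC)c2)cc1C(F)(F)F`. In a functional assay on HCT-116 cells (Homo sapiens) for antiproliferative activity, read by MTT assay, with a stated time of 48 h (on this read-out higher numbers stand for weaker inhibition and lower numbers for stronger inhibition), compound 1 gives 63800 nM. In this assay compound 2 gives 65300 nM. For compound 3, this assay returns only a limit of the assay, > 80000 nM. Compound 3 therefore sits among the high numbers shown, and an at least 1.2-fold higher number from compound 1 to compound 3 (0.09 log units; that floor lies within the scatter) as well as an at least 1.2-fold higher number from compound 2 to compound 3 (0.08 log units; that floor lies within the scatter) are both within the scatter. Compound 4 `COc1ccc(CN(C(=O)CSc2nc3ccccc3s2)c2cc(OC)c(OC)c(OC)c2)cc1` differs from compound 3 by hydrogen in place of trifluoromethyl on an aromatic carbon. Among the compounds with values here, no measured step removes a trifluoromethyl, so the two steps into compound 3 are the only guide, and they point to no change beyond the scatter in this assay. Compound 4 is therefore expected to give about 75000 nM, between 40000 nM and 150000 nM. This amounts to an expected at least 1.0-fold lower number from compound 3 to compound 4 (0.02 log units; that floor lies within the scatter).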

Compound 4, half-maximal inhibitory concentration: 426 nM
Compound 4: middle estimate off by 180-fold (2.25 log units), on the high side; the measured number lies below the stated range.
By their numbers in this assay, from the lowest: compound 4; then compounds 1 and 2 (each within the scatter of the next). At a limit, above all of these: compound 3.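

Taking the trifluoromethyl off this aromatic carbon gives an at least 180-fold lower number from compound 3 to compound 4 (2.27 log units; beyond the scatter) in this assay and so reveals a large change at a place where the earlier steps, all within the scatter, showed none. The 4-methoxyphenyl group also stands well apart from the groups of the other two compounds, with a 150-fold lower number from compound 2 to compound 4 (2.19 log units; beyond the scatter) and a 150-fold lower number from compound 1 to compound 4 (2.18 log units; beyond the scatter) as the steps. Compound 3 has only a limit, so its step is a floor: the limit of > 80000 nM in this assay, at which 1 of the 4 values shown sits.

As far as these compounds go, whether fluoro, methyl, an amine or a carboxylic acid on this carbon would keep the number near that of compound 4 remains open.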